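The compounds below may be only part of what the source reports. "The series", "measured", "known", "first", "only" and "open" are said of these compounds alone.

Working notes on the series

The shared core of compound 1 `O=C(/C=C/c1ccc2c(c1)B(O)OC2)c1ccc(OCc2ccccc2)cc1` carries a benzyloxy-substituted aryl ketone. In an ADME assay on L929 cells (Mus musculus) for cytotoxicity, read by resazurin assay, with a stated time of 72 h (on this read-out lower numbers stand for stronger inhibition and higher numbers for weaker inhibition), compound 1 gives > 10 ug/mL, which is a limit of the assay and not a number. Compound 2 `Nc1ccc(C(=O)/C=C/c2ccc3c(c2)B(O)OC3)cc1` differs by amino in place of benzyloxy on an aromatic carbon. In this assay compound 2 gives > 10 ug/mL, again a limit. Compound 3 `O=C(/C=C/c1ccc2c(c1)B(O)OC2)c1ccccn1` carries pyridin-2-yl in place of 4-aminophenyl on a carbonyl carbon. In this assay compound 3 gives > 10 ug/mL, also a limit. The steps a step that the two limits leave unreadable from compound 1 to compound 2 and a step that the two limits leave unreadable from compound 2 to compound 3 cannot be sized, because of the limit of > 10 ug/mL in this assay, at which 3 of the 3 values shown sit. Compound 2 therefore stands at the same limit as the other two values, and no ordering among the three is available.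

Compound 4 `COc1cc(C(=O)/C=C/c2ccc3c(c2)B(O)OC3)ccc1N` differs from compound 2 by methoxy in place of hydrogen on an aromatic carbon. Going by the values given here, none of the measured steps covers this change, and the two readable neighbours of compound 2 both sit at the limit. The expectation is that compound 4 shows no step beyond the scatter, a step that the limit leaves unreadable from compound 2 to compound 4. Compound 4 is thus estimated at 20 ug/mL, with a range from 8 ug/mL to 60 ug/mL, most likely reported again as a limit.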

Compound 4, half-maximal inhibitory concentration: 1.45 ug/mL
The estimate for compound 4 lay 14-fold (1.14 log units) above the measured number; measured number outside the range, below it.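

Methoxy in place of hydrogen, on an aromatic carbon ortho to an amino group and meta to a large group, gives an at least 6.8-fold lower number from compound 2 to compound 4 (0.83 log units; beyond the scatter) in this assay. This position therefore responds to a small substituent, whereas the changes among compound 1, compound 2 and compound 3 could not be read. The step is a minimum and its full size stays unknown because compound 2 sits at a limit of the assay: the limit of > 10 ug/mL in this assay, at which 3 of the 4 values shown sit.

The compounds shown leave open whether the lower number is specific to methoxy, as ethoxy, hydroxyl or fluorine at this position would test. They also leave open whether it depends on the amino group, which a methoxy-substituted partner carrying a dimethylamino group or hydrogen in its place would test.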